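The source may report more compounds than this note shows. Statements on the series, on what has been measured and on what is new or still open speak of the compounds shown alone.

Three compounds built on one shared core have so far been run through a functional assay on RAW264.7 cells (Mus musculus) for inhibition, read by Griess assay, with stated times of 2 h and 24 h; a lower number here means a stronger inhibitor, a higher number a weaker inhibitor. Compound 1 `CCn1cc(COc2cc(O)c3c(c2)O[C@H](c2ccc(OC)c(O)c2)C/C3=N\O)nn1` gives 3140 nM in this assay; compound 2 `C#CCOc1cc(O)c2c(c1)O[C@H](c1ccc(OC)c(O)c1)C/C2=N\O` gives 19100 nM; compound 3 `COc1ccc([C@@H]2CC(=O)c3c(O)cc(OCc4cn(Cc5cccc(Cl)c5)nn4)cc3O2)cc1O` gives 18200 nM. On these numbers compound 3 stands second highest of the three: its value and that of compound 2 lie within the scatter of each other, while compound 1 sits clearly lower. For the measured compounds named here, the single measured step, a 6.1-fold higher number from compound 1 to compound 2 (0.78 log units; beyond the scatter), concerns a different part of the molecule. Compound 4 `COc1ccc([C@@H]2CC(=O)c3c(O)cc(OCc4cn(Cc5ccccc5C#N)nn4)cc3O2)cc1O` differs from compound 3 in one place only: 2-cyanophenyl in place of 3-chlorophenyl on a saturated chain carbon bound to an aromatic nitrogen. Going by the values given here, no measured step touches the group on the saturated chain carbon bound to the aromatic nitrogen, so nothing among the numbers speaks for a shift in either direction. The step of a 1.0-fold lower number from compound 3 to compound 4 (0.00 log units; within the scatter) is therefore expected to stay within the scatter. For compound 4 in this assay the estimate is 18000 nM, with a range from 6000 nM to 55000 nM.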

Compound 4, half-maximal inhibitory concentration: 14600 nM
Beside the measured number, compound 4's estimate is 1.2-fold (0.09 log units) above it; measured number inside the range.
By their numbers in this assay, from the lowest: compound 1; then compounds 4, 3 and 2 (each within the scatter of the next).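

For the compounds shown here, at the saturated chain carbon bound to an aromatic nitrogen, the exchange of 3-chlorophenyl for 2-cyanophenyl gives a 1.2-fold lower number from compound 3 to compound 4 (0.10 log units; within the scatter) in this assay, the first reading of any change at this place. The chlorine leaves and a nitrile enters, adding one hydrogen-bond acceptor by count, yet the step stays within the scatter, so this exchange leaves no measurable mark on the inhibition read here. Nothing available explains this outcome.

The compounds shown leave open whether a different group at this place, such as an amine or a carboxylic acid on the phenyl ring or a longer chain before it, would carry the number beyond the scatter. They also leave open whether 3-chlorobenzyl and 2-cyanobenzyl would read alike on the core of compound 1.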